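This account rests on a few compounds, and the source may have more. Where it says the series, first, only, none or still open, it means among the compounds named here.

Going by the values given here, compound 1 `COc1ccc2c(=O)c(/C=C/C(=O)Nc3ccccc3Cl)coc2c1` is the only member of this set with a number in a functional assay on HeLa cells (Homo sapiens) for inhibition, read by MTT assay, with a stated time of 48 h; a lower number here means a stronger inhibitor, a higher number a weaker inhibitor: compound 1 gives 22400 nM. Compound 2 `O=C(/C=C/c1coc2cc(O)ccc2c1=O)NCc1ccc(F)cc1` is reported in this assay only as a limit, > 100000 nM, and therefore offers no number to set beside it. Compound 3 `COc1ccc(CNC(=O)/C=C/c2coc3cc(OC)ccc3c2=O)cc1` has not yet been measured. It differs from compound 1 in one place: 4-methoxybenzyl in place of 2-chlorophenyl on an amide-type nitrogen. Among the compounds with values here, no measured pair isolates such a change, and compound 2 differs from compound 1 in more than one place, so its limit cannot be tied to this change alone. The step from compound 1 to compound 3 is expected to be a 1.8-fold higher number from compound 1 to compound 3 (0.25 log units; within the scatter), a modest weakening that may not clear the scatter. Compound 3 is estimated to give 40000 nM in this assay, within a range from 10000 nM to 150000 nM, with a fair chance that only a limit is returned.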

Compound 3, half-maximal inhibitory concentration: > 100000 nM
Compound 3 was reported as a limit; the forecaster's own chance of this, stated with the estimate: 35%; middle value at least 2.5-fold (0.39 log units) from the limit.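

Going by these compounds alone, compound 1 and compound 3 give the first comparison that isolates this position, and the change from 2-chlorophenyl to 4-methoxybenzyl on the amide-type nitrogen comes with an at least 4.4-fold higher number from compound 1 to compound 3 (0.64 log units; beyond the scatter) in this assay. The modest activity of compound 1 therefore does not carry over to this replacement, which shows that the group on this nitrogen matters in this assay even with the rest of the structure unchanged. The step gives only a minimum size, because compound 3 is reported as a limit rather than a number: the limit of > 100000 nM in this assay, at which 2 of the 3 values shown sit.

The compounds shown do not separate the chlorine, the methoxy group and the benzyl form of the ring as the source of the change. A 2-chlorobenzyl or 4-methoxyphenyl group on the same nitrogen would bear on this question.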